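A few compounds are considered here, and "the series" means these few. Any claim that something is new, unique, unknown or untested is made for them only; others in the source may bear on it.

Measured in a functional assay on MCF7 cells (Homo sapiens) for antiproliferative activity, read by MTT assay, with a stated time of 72 h; on this read-out lower numbers stand for stronger inhibition and higher numbers for weaker inhibition (every value is a limit of the assay, not a number)
Compound 1 `COc1cc(-n2ncnc2-c2ccc(Cl)cc2)cc(OC)c1OC` gives > 10000 nM
Compound 2 `COc1cc(-c2ncnn2-c2ccc(F)cc2)cc(OC)c1OC` gives > 10000 nM
Compound 3 `COc1cc(-c2ncnn2-c2ccc(N)cc2)cc(OC)c1OC` gives > 10000 nM

Compound 1 thus stands at the limit of > 10000 nM in this assay, at which 3 of the 3 values shown sit, and offers no exact starting point. Compound 4 `COc1cc(-n2ncnc2-c2ccccc2)cc(OC)c1OC` follows from compound 1 by the change hydrogen in place of chloro on an aromatic carbon (hydrogen in place of chloro on an aromatic carbon, so 4-chlorophenyl to phenyl). Among the measured compounds shown here, the only measured step that bears on this, also a swap on an aromatic carbon, is a step that the two limits leave unreadable from compound 2 to compound 3 and it gives no size to carry over. In this assay the expected step is a step that the limit leaves unreadable from compound 1 to compound 4 with no shift beyond the scatter expected in either direction. Compound 4 is estimated at 15000 nM (expected range 5000 nM to 50000 nM) and may well be reported as a limit too.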

Compound 4, half-maximal inhibitory concentration: > 10000 nM
Compound 4: only a limit was reported; the forecaster's own chance of this, stated with the estimate: 80%; the middle value does not contradict the limit.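

Compound 1 and compound 4 are both reported only as a limit of the assay, so no size can be read for the change between them: the limit of > 10000 nM in this assay, at which 4 of the 4 values shown sit.

The compounds shown leave open how strongly any of them inhibits, and whether 4-chlorophenyl and phenyl differ at all.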